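Cytotoxicity across two matched pairs on related cores

The source may hold more compounds than are shown below. What is called first, only, known or untested is meant among the compounds shown, and "the series" means these compounds.

Three compounds were measured in an ADME assay on MT4 cells (Homo sapiens) for cytotoxicity, read by MTT assay, with a stated time of 5 days; on this read-out higher numbers stand for lower toxicity in this test and lower numbers for higher toxicity in this test. Compound 1 `Cc1cc(/C=C/C#N)cc(C)c1Oc1nc(Nc2ccc(N3CCCC(N)C3)cc2)nc2ccsc12` gives 3820 nM in this assay. Compound 2 `Cc1cc(/C=C/C#N)cc(C)c1Oc1nc(Nc2ccc(N3CCN(S(C)(=O)=O)CC3)cc2)nc2ccsc12`, which carries 4-(methylsulfonyl)piperazin-1-yl in place of 3-aminopiperidin-1-yl on an aromatic carbon, gives 11500 nM in this assay. That single change made a 3.0-fold higher number from compound 1 to compound 2 (0.48 log units; beyond the scatter). Compound 3 `Cc1cc(/C=C/C#N)cc(C)c1Oc1nc(Nc2ccc(N3CCCC(N)C3)cc2)nc2sccc12` shares its atoms with compound 1 but joins them differently; the difference between the two cores is not broken down here. In this assay compound 3 gives 4610 nM, which stands within the scatter of the value of compound 1 and beyond the scatter from the value of compound 2.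

Compound 4 `Cc1cc(/C=C/C#N)cc(C)c1Oc1nc(Nc2ccc(N3CCN(S(C)(=O)=O)CC3)cc2)nc2sccc12` has not yet been measured. It relates to compound 3 exactly as compound 2 relates to compound 1: it carries 4-(methylsulfonyl)piperazin-1-yl in place of 3-aminopiperidin-1-yl on an aromatic carbon, and the place of the change is described in the same words for both pairs, so this is the same change made on the core of compound 3. Among the measured compounds shown here, the only precedent is the step from compound 1 to compound 2, and the values of compound 1 and compound 3 lie within the scatter of each other, which gives no reason to expect the core of compound 3 to respond differently. On that basis the step from compound 3 to compound 4 is expected to be a 2.9-fold higher number from compound 3 to compound 4 (0.47 log units; beyond the scatter), close to the earlier one. Compound 4 is therefore estimated to give 13500 nM, with a likely range from 6500 nM to 28000 nM, in this assay.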

Compound 4, half-maximal cytotoxic concentration: > 222000 nM
Compound 4: no number, only a limit (the forecaster's own chance of this, stated with the estimate: 15%); middle value at least 16-fold (1.21 log units) away from the limit.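

Carrying the change from 3-aminopiperidin-1-yl to 4-(methylsulfonyl)piperazin-1-yl over to the core of compound 3 kept the direction of the earlier step in this assay, giving an at least 48-fold higher number from compound 3 to compound 4 (1.68 log units; beyond the scatter), but the size of the step did not carry over from one core to the other: the same change on two cores in this assay, a 3.0-fold higher number (0.48 log units; beyond the scatter) from compound 1 to compound 2 and an at least 48-fold higher number (1.68 log units; beyond the scatter) from compound 3 to compound 4, at least 15-fold (1.20 log units) apart, beyond the scatter of two such steps

Compound 4 gives > 222000 nM in this assay, which is a limit of the assay and not a number, so the full size of the step stays unknown and only its smallest possible size can be read: the limit of > 222000 nM in this assay, at which 1 of the 4 values shown sits.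

What this does not show is why the two cores respond so differently, and with a single pair on each core it cannot say whether the core of compound 3 would magnify any other change in the same way.

The compounds shown leave open whether the larger step belongs to 4-(methylsulfonyl)piperazin-1-yl alone or would also appear on this core with a morpholine, or with an acetyl group in place of the methylsulfonyl on the piperazine. They also leave open how an unsubstituted piperazine would behave on each of the two cores.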